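From compound 1 to compound 3: a longer chain

The compounds below may be only part of what the source reports. "The series", "measured", "known", "first", "only" and "open" are said of these compounds alone.

Compound 1 `CN1CCN(CCCCn2c3c(c4ccccc42)C(=O)c2c[n+]([O-])c4ccccc4c2C3=O)CC1` gives 100 nM
Compound 2 `CC1(C)OC[C@H](Cn2cc(Cn3c4c(c5ccccc53)C(=O)c3c[n+]([O-])c5ccccc5c3C4=O)nn2)O1` gives 820 nM

In a functional assay on SH-SY5Y cells (Homo sapiens) for cytotoxicity, read by MTT assay, with a stated time of 72 h (a higher number here means a weaker inhibitor, a lower number a stronger inhibitor), compound 1 holds the lower of the two numbers, and compound 2 sits above it by more than the usual scatter. Compound 3 `CN1CCN(CCCCCCn2c3c(c4ccccc42)C(=O)c2c[n+]([O-])c4ccccc4c2C3=O)CC1` differs from compound 1 in one place (2-(4-methylpiperazin-1-yl)ethyl in place of 4-methylpiperazin-1-yl on a saturated chain carbon, four bonds along the chain from an aromatic nitrogen), with 2-(4-methylpiperazin-1-yl)ethyl in place of 4-methylpiperazin-1-yl on a saturated chain carbon, four bonds along the chain from an aromatic nitrogen. Among the compounds with values here, no measured pair shows this kind of change, so no step beyond the scatter is expected (a 1.3-fold higher number from compound 1 to compound 3 (0.11 log units; within the scatter)). Compound 3 is expected at 130 nM (estimated range 40 nM to 450 nM).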

Compound 3, half-maximal inhibitory concentration: 920 nM
Compound 3: middle estimate off by 7.1-fold (0.85 log units), on the low side, outside the stated range (above it).
By their numbers in this assay, from the lowest: compound 1; then compounds 2 and 3 (each within the scatter of the next).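

Chain length matters at this position: in this assay, 2-(4-methylpiperazin-1-yl)ethyl in place of 4-methylpiperazin-1-yl gives a 9.2-fold higher number from compound 1 to compound 3 (0.96 log units; beyond the scatter), making the longer-chain compound the weaker inhibitor. The six-membered ring at the chain end and its hydrogen-bond counts stay the same, so this change adds only chain length. The data shown offer no explanation for this step.

On these data alone, whether 5-(4-methylpiperazin-1-yl)pentyl would fall between these two remains open. So does whether 3-(4-methylpiperazin-1-yl)propyl, with a shorter chain, would give a lower number.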